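Swapping fluoro for chloro on the benzyl ring

The source may report more compounds than this note shows. Statements on the series, on what has been measured and on what is new or still open speak of the compounds shown alone.

compound 1 `Cc1ccc(/C=C2\CN(Cc3cn(Cc4cccc(Cl)c4)nn3)C/C(=C\c3ccc(C)cc3)C2=O)cc1` gives 9000 nM here
compound 2 `Cc1ccc(/C=C2\CN(Cc3cn(Cc4ccccc4F)nn3)C/C(=C\c3ccc(C)cc3)C2=O)cc1` gives 10000 nM here

Among the compounds with values here, in a functional assay on MDA-MB-231 cells (Homo sapiens) for cytotoxicity, read by MTT assay, with a stated time of 24 h (on this read-out higher numbers stand for weaker inhibition and lower numbers for stronger inhibition), compound 2 gives 10000 nM and sits level with compound 1, the only other measured compound. Compound 3 `Cc1ccc(/C=C2\CN(Cc3cn(Cc4ccccc4Cl)nn3)C/C(=C\c3ccc(C)cc3)C2=O)cc1` differs from compound 2 by chloro in place of fluoro on an aromatic carbon and so has chloro in place of fluoro on an aromatic carbon, turning 2-fluorobenzyl into 2-chlorobenzyl. Within the data shown here, the only measured step, a 1.1-fold higher number from compound 1 to compound 2 (0.05 log units; within the scatter) with 2-fluorophenyl in place of 3-chlorophenyl, stays within the scatter, so no step beyond the scatter is expected in this assay for this swap. The estimated change is a 1.1-fold lower number from compound 2 to compound 3 (0.02 log units; within the scatter) in size. For compound 3 the estimated value is 9500 nM with an expected range from 5000 nM to 18000 nM on this read-out.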

Compound 3, half-maximal inhibitory concentration: 29000 nM
Estimate against measurement, compound 3: 3.1-fold (0.48 log units) below; the whole stated range lies below it.
By their numbers in this assay, from the lowest: compounds 1 and 2 (each within the scatter of the next); then compound 3.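

In this assay, the identity of the halogen on this ring does matter: chloro in place of fluoro gives a 2.9-fold higher number from compound 2 to compound 3 (0.46 log units; beyond the scatter), a modest loss of inhibition. Where the chloro sits matters too, as 2-chlorophenyl in place of 3-chlorophenyl gives a 3.2-fold higher number from compound 1 to compound 3 (0.51 log units; beyond the scatter), again a modest loss. Nothing available explains either step. Still open, going by these compounds, is how a methoxy group or a methyl group on this ring would compare with chloro and fluoro. Also open, on these data alone, is whether a plain benzyl group, with no halogen, would read closer to compound 2 or compound 3.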